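The source may report more compounds than this note shows. Statements on the series, on what has been measured and on what is new or still open speak of the compounds shown alone.

- Compound 1 `Cc1ccc(/C=C2\CCc3ccccc3C2=O)cc1`: 460000 nM
- Compound 2 `O=C1CCCCC/C1=C\c1cccc(F)c1`: 224000 nM
- Compound 3 `O=C1CCCCC/C1=C\c1cccc(Cl)c1`: 40500 nM

In a functional assay on CCRF-CEM cells (Homo sapiens) for inhibition (on this read-out lower numbers stand for stronger inhibition and higher numbers for weaker inhibition), compound 3 gives 40500 nM, the lowest of the three numbers, so it is the strongest inhibitor measured so far. Compound 4 `Cc1cccc(/C=C2\CCCCCC2=O)c1` differs from it in one place: methyl in place of chloro on an aromatic carbon.

Within the data shown here, one measured step bears directly on this swap: a 5.5-fold lower number from compound 2 to compound 3 (0.74 log units; beyond the scatter), also a change of a single group on an aromatic carbon. Compound 1 carries a methyl too, but its core differs, so it offers little guidance. No measurement shows how methyl compares with chloro on the core of compound 3. Among the measured compounds shown here, the one swap of chloro for another group, seen in reverse in that step, gave a higher number, so a smaller step in the same direction seems the safest expectation. The estimated change is a 2.1-fold higher number from compound 3 to compound 4 (0.32 log units; beyond the scatter). For compound 4 the estimated value is 85000 nM, with an expected range from 30000 nM to 220000 nM.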

Compound 4, half-maximal inhibitory concentration: 170000 nM
Compound 4: middle estimate off by 2.0-fold (0.30 log units), on the low side; the measured number falls inside the stated range.
By their numbers in this assay, from the lowest: compound 3; then compounds 4 and 2 (each within the scatter of the next); then compound 1.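

In this assay, replacing chloro with methyl on this aromatic carbon gives a 4.2-fold higher number from compound 3 to compound 4 (0.62 log units; beyond the scatter), so the advantage of chloro on the shared core now holds against two groups rather than fluoro alone. Methyl and fluoro, by contrast, cannot be told apart at this position, with a 1.3-fold lower number from compound 2 to compound 4 (0.12 log units; within the scatter) lying within the usual scatter, which leaves chloro as the one group of the three that stands out here. Nothing available explains why chloro differs from the other two groups.

As far as these compounds go, whether a larger halogen such as bromo, or a group such as methoxy or nitrile, would match chloro at this position remains open. So does whether chloro would keep its advantage on the core of compound 1.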